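Amide replacement on the pyridine-naphthyl series

The compounds below may be only part of what the source reports. "The series", "measured", "known", "first", "only" and "open" are said of these compounds alone.

Measured compounds:
compound 1, `CN1CCN(C(=O)/C=C/c2ccncc2-c2ccc3ccccc3c2)CC1`: 43.6 nM
compound 2, `O=C(O)[C@@H]1CCCN1C(=O)/C=C/c1ccncc1-c1ccc2ccccc2c1`: "not determined" (no result reported)
compound 3, `O=C(O)CCc1ccncc1-c1ccc2ccccc2c1`: 50.5 nM

In an assay on a protein complex for inhibition of CDK8/Cyclin C (Homo sapiens), with a stated time of 1 h (on this read-out lower numbers stand for stronger inhibition and higher numbers for weaker inhibition), compound 3 gives 50.5 nM and compound 1 gives 43.6 nM. Compound 3 has the higher of the two numbers, but the gap to compound 1 lies within the scatter, so the two stand level on this read-out. Compound 2 carries a proline acid on the same core and has no result in this assay.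

Compound 4, `O=C(/C=C/c1ccncc1-c1ccc2ccccc2c1)NC1CC1`, is the next step from compound 3. The change is 2-(cyclopropylcarbamoyl)ethenyl in place of 2-carboxyethyl on an aromatic carbon, ortho to a large group and opposite the ring nitrogen. Compound 1, an amide on the same unsaturated linker, sits level with the acid of compound 3, so no step beyond the scatter is expected for another small amide. Compound 4 is estimated at 40 nM, range 15 nM to 110 nM, which means an expected step of a 1.3-fold lower number from compound 3 to compound 4 (0.10 log units; within the scatter).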

Compound 4, half-maximal inhibitory concentration: 40.1 nM
Compound 4: the middle estimate sits 1.0-fold (0.00 log units) below what was measured; the range from low to high includes it.
By their numbers in this assay, from the lowest: compounds 4, 1 and 3 (each within the scatter of the next).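

In this assay, 2-(cyclopropylcarbamoyl)ethenyl in place of 2-carboxyethyl on the aromatic carbon, ortho to a large group and opposite the ring nitrogen, gives a 1.3-fold lower number from compound 3 to compound 4 (0.10 log units; within the scatter), so the read-out stays level with a secondary amide carrying a three-membered carbon ring at this position. On the carbonyl carbon, cyclopropylamino in place of 4-methylpiperazin-1-yl gives a 1.1-fold lower number from compound 1 to compound 4 (0.04 log units; within the scatter), so the two amides on the same unsaturated linker also stand level. No measurement shown here explains why these values stand level.

The linker and the end group both differ between compound 3 and compound 4, so the shown values do not separate their contributions. As far as these compounds go, whether a primary amine on a longer chain or a hydroxyl group at this position would stand level remains open.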